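This account rests on a few compounds, and the source may have more. Where it says the series, first, only, none or still open, it means among the compounds named here.

In an ADME assay on MRC5 cells (Homo sapiens) for cytotoxicity, read by fluorescence and resazurin assay, with a stated time of 3 days (on this read-out higher numbers stand for weaker inhibition and lower numbers for stronger inhibition), compound 1 `Cc1cn(C2CCN(Cc3cccc(OC4CCCC4)c3)CC2)c(=O)[nH]c1=O` gives 30300 nM. Compound 2 `Cc1cccc(Oc2cccc(CN3CCC(n4cc(C)c(=O)[nH]c4=O)CC3)c2)c1` gives > 64000 nM, which is a limit of the assay and not a number. The data show an at least 2.1-fold higher number from compound 1 to compound 2 (0.32 log units; beyond the scatter), a step that put 3-methylphenyl in place of cyclopentyl on the same oxygen. Compound 3 `COc1ccc(Oc2cccc(CN3CCC(n4cc(C)c(=O)[nH]c4=O)CC3)c2)cc1` changes that group again, with 4-methoxyphenyl in place of 3-methylphenyl on an oxygen on an aromatic ring. Only two things bear on this change: that single step, and (the limit of > 64000 nM in this assay, at which 1 of the 2 values shown sits). Neither measures a swap between two aromatic groups, so no clear shift in this assay can be predicted, and no step beyond the scatter is expected. The expected step is an at least 1.1-fold lower number from compound 2 to compound 3 (0.04 log units; that floor lies within the scatter). The estimate for compound 3 is 58000 nM, within an expected range of 26000 nM to 64000 nM.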

Compound 3, half-maximal inhibitory concentration: 28000 nM
The estimate for compound 3 lay 2.1-fold (0.32 log units) above the measured number; the range from low to high includes it.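

With 4-methoxyphenyl in place of 3-methylphenyl on the oxygen, this assay shows an at least 2.2-fold lower number from compound 2 to compound 3 (0.35 log units; beyond the scatter), so two aromatic groups at this place can give different read-outs, and an aromatic group here does not by itself bring weaker inhibition. Set against cyclopentyl, 4-methoxyphenyl gives a 1.1-fold lower number from compound 1 to compound 3 (0.03 log units; within the scatter), so these two groups cannot be told apart in this read-out. The value of compound 2 is a limit of the assay and not a number, so the full size of its step stays unknown: the limit of > 64000 nM in this assay, at which 1 of the 3 values shown sits.

The 3-methylphenyl and 4-methoxyphenyl groups differ both in what the aromatic ring carries and in where it carries it, and the compounds shown do not separate these two differences. As far as these compounds go, how an amine or a carboxylic acid in place of the methoxy group would read in this assay also remains open.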